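Fluoro to Pyridin-3-yl on a Cytotoxic Imidazopyridine

The source may report more compounds than this note shows. Statements on the series, on what has been measured and on what is new or still open speak of the compounds shown alone.

Compound 2 `Fc1ccc(-c2nc3cccnc3n2C2CCCC2)cc1` gives 500 nM in a functional assay on MDA-MB-231 cells (Homo sapiens) for cytotoxicity, read by MTT assay, with a stated time of 24 h; on this read-out lower numbers stand for stronger inhibition and higher numbers for weaker inhibition. Among the three compounds with numbers, compound 2 stands second highest. Compound 3 `Cc1ccsc1-c1nc2cccnc2n1C1CCCC1` gives 138 nM in this assay, and the step from compound 2 to compound 3 is a 3.6-fold lower number from compound 2 to compound 3 (0.56 log units; beyond the scatter). Going by the values given here, compound 1 `c1ccc(-c2nc3ncccc3n2C2CCCC2)cc1` gives 7000 nM in this assay, the highest of the three numbers, though no single-point step links it to compound 2.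

Compound 4 `c1cncc(-c2ccc(-c3nc4cccnc4n3C3CCCC3)cc2)c1` is not yet measured. Its change from compound 2 is pyridin-3-yl in place of fluoro on an aromatic carbon. Among the compounds with values here, the only measured step, from compound 2 to compound 3, exchanged the whole 4-fluorophenyl and so bears on this change only loosely; it shows that alterations in this part of the molecule can move the number beyond the scatter, but says nothing about a pyridin-3-yl entering where the fluoro sat, para to a large group. A modest step is therefore expected, with some lean toward a lower number. Compound 4 is estimated at 350 nM in this assay, with a range from 90 nM to 1400 nM. This estimate means a step of a 1.4-fold lower number from compound 2 to compound 4 (0.15 log units; within the scatter).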

Compound 4, half-maximal inhibitory concentration: > 10000 nM
Compound 4 gave a limit, no number; the forecaster's own chance of this, stated with the estimate: 5%; at least 28-fold (1.45 log units) between middle value and limit.
By their numbers in this assay, from the lowest: compound 3; then compound 2; then compound 1. At a limit, above all of these: compound 4.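

Putting pyridin-3-yl in place of fluoro on this aromatic carbon, para to a large group, gives an at least 20-fold higher number from compound 2 to compound 4 (1.30 log units; beyond the scatter) in this assay. The earlier step, a 3.6-fold lower number from compound 2 to compound 3 (0.56 log units; beyond the scatter), exchanged the whole 4-fluorophenyl and lowered the number modestly, whereas this change, made on the ring that stays, raises it by a large step. Compound 4 gives only a limit of the assay rather than a number, so the full size of the step remains unknown: the limit of > 10000 nM in this assay, at which 1 of the 4 values shown sits.

The compounds shown leave open whether a phenyl, a methoxy or an amine on this carbon would behave like the fluoro or like pyridin-3-yl. They also do not separate the effect of the added ring from that of its nitrogen, and they give no cause for the rise.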